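Working notes: the step from compound 1 to compound 4

The source may report more compounds than this note shows. Statements on the series, on what has been measured and on what is new or still open speak of the compounds shown alone.

- compound 1 `O=C1NC(O)(CCn2cnc3cc[nH]c3c2=O)C(OCc2ccccc2)=C1OCc1ccccc1`: 36600 nM
- compound 2 `O=C1O/C(=C\Cn2cnc3cncc(Br)c32)C(OCc2ccccc2)=C1OCc1ccccc1`: 22600 nM
- compound 3 `O=C1NC(O)(CCn2cnc3ccn(CCC4(O)NC(=O)C(OCc5ccccc5)=C4OCc4ccccc4)c3c2=O)C(OCc2ccccc2)=C1OCc1ccccc1`: 5700 nM; 4400 nM (2 entries)

All values come from a functional assay on MIA PaCa-2 cells (Homo sapiens) for antiproliferative activity, read by MTT assay, with a stated time of 72 h; a higher number here means a weaker inhibitor, a lower number a stronger inhibitor. Compound 1 gives 36600 nM and compound 2 gives 22600 nM, so these two lie within the scatter of each other and cannot be ranked. Compound 3 was measured more than once, as the several entries of compound 3 in this assay, 5700 nM; 4400 nM (2 entries) shows, and both of its numbers are lower than those of compound 1 and compound 2.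

Compound 4 `O=C1NC(O)(CCn2cnc3cncc(Br)c32)C(OCc2ccccc2)=C1OCc1ccccc1` has not yet been measured. It keeps the core of compound 1 and changes one group: a group of 10 heavy atoms (6 carbon, 3 nitrogen, 1 bromine; one five-membered aromatic ring with 2 hetero atoms, one six-membered aromatic ring with 1 hetero atom) in place of a group of 10 heavy atoms (6 carbon, 3 nitrogen, 1 oxygen; one five-membered aromatic ring with 1 hetero atom, one six-membered aromatic ring with 2 hetero atoms), on a saturated chain carbon, two bonds along the chain from a saturated ring carbon. Among the measured compounds shown here, no measured pair isolates this exchange, so its effect in this assay cannot be read directly from the data. The expectation therefore rests on the narrow band formed by compound 1 at 36600 nM and compound 2 at 22600 nM. No shift beyond the scatter is expected in either direction. The estimated change is small, a 1.4-fold lower number from compound 1 to compound 4 (0.15 log units; within the scatter), and the range is kept wide because only a few compounds inform it.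

For compound 4 the expected value is 26000 nM, with an estimated range from 9000 nM to 75000 nM.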

Compound 4, half-maximal inhibitory concentration: 48700 nM
Estimate against measurement, compound 4: 1.9-fold (0.27 log units) below, and the stated range covers the measured number.
By their numbers in this assay, from the lowest: compounds 2, 1 and 4 (each within the scatter of the next, the first and the last beyond it).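

In this assay, among the compounds shown here, the exchange on a saturated chain carbon, two bonds along the chain from a saturated ring carbon, gives a 1.3-fold higher number from compound 1 to compound 4 (0.12 log units; within the scatter) as the first direct reading of a change at this place. The two groups therefore cannot be ranked here, even though the entering group carries a bromine and 0 hydrogen-bond donors while the leaving group carries an oxygen, 1 hydrogen-bond donor and 1 double bond outside aromatic rings. Nothing in the available evidence bears on why this exchange gives this result.

As far as these compounds go, the exchange alters the ring hetero atoms and brings in the bromine in a single step, so the separate contribution of each remains open, and a matching group with hydrogen in place of the bromine would help to separate them. From the compounds shown here alone, it also remains open whether any other group at this place, such as an amine or a carboxylic acid, or a longer chain carrying either of these two groups, would move the number beyond the scatter.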